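Adding a methoxycarbonyl group to compound 1

A few compounds are considered here, and "the series" means these few. Any claim that something is new, unique, unknown or untested is made for them only; others in the source may bear on it.

- compound 1 `CC(O)(C(=O)Nc1ccccc1Cl)C(F)(F)F` gives 5400 nM
- compound 2 `CC(=O)c1ccccc1NC(=O)C(C)(O)C(F)(F)F` gives 14000 nM
- compound 3 `COC(=O)c1cccc(NC(=O)C(C)(O)C(F)(F)F)c1Cl` is not yet measured

Of the two compounds measured in a functional assay on the whole organism with Homo sapiens as the target (a higher number here means that more compound is needed for the effect, a lower number that less compound is needed), compound 1 stands lowest, at 5400 nM. Compound 3 keeps the chloro group of compound 1 and differs by methoxycarbonyl in place of hydrogen on an aromatic carbon. Within the data shown here, only one measured step bears on this change: a 2.6-fold higher number from compound 1 to compound 2 (0.41 log units; beyond the scatter), a modest one. It replaces the chloro group itself, so it is only a loose guide. A similarly modest rise in this assay is expected, with the estimated step being a 2.2-fold higher number from compound 1 to compound 3 (0.35 log units; beyond the scatter). For compound 3 the expected value is 12000 nM, with an estimated range of 3500 nM to 40000 nM.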

Compound 3, half-maximal effective concentration: 13800 nM
Compound 3: the middle estimate sits 1.2-fold (0.06 log units) below what was measured; low and high end bracket the measured number.
By their numbers in this assay, from the lowest: compound 1; then compounds 3 and 2 (each within the scatter of the next).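

In this assay, methoxycarbonyl in place of hydrogen on the aromatic carbon ortho to the chloro group gives a 2.6-fold higher number from compound 1 to compound 3 (0.41 log units; beyond the scatter) while the chloro group stays in place. Among these compounds, the earlier step changed the chloro group itself, so this is the first view of a ring position that carries hydrogen in compound 1, and filling it here does not lower the number. Nothing measured at hand accounts for this rise. As far as these compounds go, whether a methyl group or a carboxylic acid at this same place would give a similar rise stays open. From the compounds shown here alone, it also stays open whether any group here raises the number, or only methoxycarbonyl does.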